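Compound 4: A Larger Group on the Carbonyl Carbon

This account rests on a few compounds, and the source may have more. Where it says the series, first, only, none or still open, it means among the compounds named here.

Of the compounds shown here, three built on one shared core have been tested in a functional assay on MCF7 cells (Homo sapiens), read by MTT assay, with a stated time of 48 h; a higher number here means a weaker inhibitor, a lower number a stronger inhibitor. Compound 1 `CCn1c(C(=O)NCCCN(C)C)ccc1C(CC)(CC)c1ccc(OCC(=O)C(C)(C)C)c(C)c1` gives 340 nM, compound 2 `CCn1c(C(=O)NCCN)ccc1C(CC)(CC)c1ccc(OCC(=O)C(C)(C)C)c(C)c1` gives 75 nM, and compound 3 `CCn1c(C(=O)NCCCN(C)C)ccc1C(CC)(CC)c1ccc(OCC(O)C(C)(C)C)c(C)c1` gives 490 nM. Compound 3 carries the highest number of the three: the step of a 1.4-fold higher number from compound 1 to compound 3 (0.16 log units; within the scatter) is within the scatter, while compound 2 sits well apart from it.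

Compound 4 `CCn1c(C(=O)Oc2ccc(CCO)cc2)ccc1C(CC)(CC)c1ccc(OCC(O)C(C)(C)C)c(C)c1` differs from compound 3 at the carbonyl carbon: a group of 10 heavy atoms (8 carbon, 2 oxygen; one six-membered aromatic ring of carbon only) in place of a group of 7 heavy atoms (5 carbon, 2 nitrogen; no ring), on a carbonyl carbon. For the measured compounds named here, no measured step covers such a change. Going by the values given here, the only step touching that side of the molecule, a 4.5-fold lower number from compound 1 to compound 2 (0.66 log units; beyond the scatter), shows that what hangs from the carbonyl carbon can shift the number noticeably, but compound 4 drops the nitrogen-bearing chain altogether, so that step offers no direction. The author therefore expects a step of about a 1.3-fold higher number from compound 3 to compound 4 (0.12 log units; within the scatter), which would not stand beyond the scatter. Compound 4 is estimated at 650 nM, with a range from 150 nM to 2800 nM.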

Compound 4, half-maximal inhibitory concentration: > 50000 nM
Compound 4 gave a limit, no number; the forecaster's own chance of this, stated with the estimate: 10%; middle value at least 76-fold (1.88 log units) away from the limit.
By their numbers in this assay, from the lowest: compound 2; then compounds 1 and 3 (each within the scatter of the next). At a limit, above all of these: compound 4.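

In this assay compound 4 reads only as a limit, not as a number: the limit of > 50000 nM in this assay, at which 1 of the 4 values shown sits. For the compounds shown here, the change on the carbonyl carbon, where the (3-(dimethylamino)propyl)amino group leaves and a group with a six-membered aromatic ring of carbon only enters, gives an at least 100-fold higher number from compound 3 to compound 4 (2.00 log units; beyond the scatter), well beyond the only earlier step on that side, a 4.5-fold lower number from compound 1 to compound 2 (0.66 log units; beyond the scatter). The earlier compounds shown here showed only a modest shift at this position among nitrogen-bearing chains, whereas this change shows that a group without nitrogen can end in a limit.

The compounds shown do not separate the effect of the aromatic ring from that of losing the amine-bearing chain. From the compounds shown here alone, a phenylamino group on the carbonyl carbon, which keeps the ring and the amide-type nitrogen, or a carboxylic acid there, remains open.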